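Plasma half-life in a bis-ester series: compound 4

The compounds below may be only part of what the source reports. "The series", "measured", "known", "first", "only" and "open" are said of these compounds alone.

Measured compounds in an ADME assay on a cell-free system (plasma, Homo sapiens) for metabolic stability, with Plasma (Rattus norvegicus) as the target, read by HPLC, at pH 7.4; a lower number here means that the compound disappears faster, a higher number that the compound lasts longer:
compound 1 `CC(=O)Oc1ccccc1C(=O)O[C@H]1CO[C@H]2[C@@H]1OC[C@H]2OC(=O)c1snnc1C`: 0.0642 h
compound 2 `CC(=O)Oc1ccccc1C(=O)O[C@H]1CO[C@H]2[C@@H]1OC[C@H]2OC(=O)c1cccc(O)c1`: 0.0183 h
compound 3 `CC(=O)Oc1ccccc1C(=O)O[C@H]1CO[C@H]2[C@@H]1OC[C@H]2OC(=O)c1ccc([N+](=O)[O-])cc1`: 0.0462 h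

Compound 2 holds the lowest number of the three in this assay. The gap to compound 3 is a 2.5-fold higher number from compound 2 to compound 3 (0.40 log units; beyond the scatter), and the step from compound 1 is a 3.5-fold lower number from compound 1 to compound 2 (0.55 log units; beyond the scatter); both lie beyond the scatter, so the 3-hydroxyphenyl ester is set apart from the other two. The step of a 1.4-fold lower number from compound 1 to compound 3 (0.14 log units; within the scatter) stays within the scatter.

Compound 4 `CC(=O)Oc1ccccc1C(=O)O[C@H]1CO[C@H]2[C@@H]1OC[C@H]2OC(=O)c1cccc(CO[N+](=O)[O-])c1` differs from compound 2 by (nitrooxy)methyl in place of hydroxy on an aromatic carbon. The two steps that reach compound 2 both run in the same sense: whenever the hydroxy-bearing aryl is absent, the number rises by a modest amount. Among the compounds with values here, the step to compound 4 removes that hydroxy and so is expected to move in the same direction, by a size comparable to a 2.5-fold higher number from compound 2 to compound 3 (0.40 log units; beyond the scatter), though no measured pair carries the (nitrooxy)methyl group itself, so the range is kept wide.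

The estimated step is a 2.2-fold higher number from compound 2 to compound 4 (0.34 log units; beyond the scatter). For compound 4 the expected half-life in this assay is 0.04 h, with a range of 0.015 h to 0.1 h.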

Compound 4, half-life: 0.0433 h
Compound 4: the middle estimate sits 1.1-fold (0.03 log units) below what was measured, within the range that was stated.
By their numbers in this assay, from the lowest: compound 2; then compounds 4, 3 and 1 (each within the scatter of the next).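

In this assay, within the data shown here, the step to (nitrooxy)methyl, a 2.4-fold higher number from compound 2 to compound 4 (0.37 log units; beyond the scatter), is the first to keep the aromatic ring and change only the group on it, and it shows that the change at this one aromatic carbon is enough to move the number beyond the scatter. The other two steps, a 1.1-fold lower number from compound 3 to compound 4 (0.03 log units; within the scatter) and a 1.5-fold lower number from compound 1 to compound 4 (0.17 log units; within the scatter), both lie within the scatter, so the three esters without the hydroxy group cannot be told apart here and only the 3-hydroxyphenyl ester stands apart. No measurement shown bears on what lies behind this shift.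

The compounds shown leave open whether the rise goes with the loss of the hydroxy or with the (nitrooxy)methyl group itself. A hydroxymethyl or a methyl group on the same aromatic carbon would separate these two readings.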